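From fluoro to trifluoromethyl: expecting a step within the scatter

The source may report more compounds than this note shows. Statements on the series, on what has been measured and on what is new or still open speak of the compounds shown alone.

In a functional assay on SMMC-7721 cells (Homo sapiens) for cytotoxicity, read by MTT assay, with a stated time of 24 h (on this read-out lower numbers stand for stronger inhibition and higher numbers for weaker inhibition), compound 1 `O=C1/C(=C/c2ccncc2)CNC/C1=C\c1ccccc1F` gives 18400 nM. Compound 2 `Cc1ccc(S(=O)(=O)N2C/C(=C\c3ccncc3)C(=O)/C(=C/c3ccccc3F)C2)cc1` gives 13200 nM. That is a 1.4-fold lower number from compound 1 to compound 2 (0.14 log units; within the scatter), so these two stand level. For compound 3 `O=C1/C(=C/c2ccncc2)CN(S(=O)(=O)c2ccc(F)cc2)C/C1=C\c1ccccc1F` the assay reports only a limit, > 20000 nM.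

Compound 4 `O=C1/C(=C/c2ccncc2)CNC/C1=C\c1ccccc1C(F)(F)F` differs from compound 1 by a single change, trifluoromethyl in place of fluoro on an aromatic carbon. Within the data shown here, no measured step touches that place. The closest swap on an aromatic carbon, made elsewhere on the molecule, is an at least 1.5-fold higher number from compound 2 to compound 3 (0.18 log units; that floor lies within the scatter). No change beyond the scatter is therefore expected in this assay, and the expected step is a 1.2-fold lower number from compound 1 to compound 4 (0.06 log units; within the scatter). The estimated value for compound 4 is 16000 nM, with an expected range of 8000 nM to 20000 nM.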

Compound 4, half-maximal inhibitory concentration: 4500 nM
Beside the measured number, compound 4's estimate is 3.6-fold (0.55 log units) above it; measured number below the stated range.
By their numbers in this assay, from the lowest: compound 4; then compounds 2 and 1 (each within the scatter of the next). At a limit, above all of these: compound 3.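

Among the steps shown in this assay, only this change on the aromatic carbon lies beyond the scatter: a 4.1-fold lower number from compound 1 to compound 4 (0.61 log units; beyond the scatter). This place on the molecule therefore responds to the group it carries, whereas the step at the amine nitrogen from compound 1 to compound 2 stayed within the scatter. Nothing shown here gives a cause for this step.

The compounds shown leave open how a methoxy group or a chlorine at this place would compare. They also leave open whether trifluoromethyl gives a similar step when the amine nitrogen carries a (4-methylphenyl)sulfonyl group.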